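Replacing a butyl chain with pyrazin-2-yl on a fused aminonitrile core

A few compounds are considered here, and "the series" means these few. Any claim that something is new, unique, unknown or untested is made for them only; others in the source may bear on it.

Measured so far:
compound 1 `N#Cc1c(N)nc2nc(C3CCCCC3)ncc2c1N` — 81000 nM
compound 2 `CCCCc1nc(C(C)(C)C)nc2nc(N)c(C#N)c(N)c12` — 6000 nM

In a physicochemical assay for solubility, in phosphate buffer, with a stated time of 18 h (a lower number here means a less soluble compound, a higher number a more soluble compound), compound 1 gives 81000 nM. In this assay compound 2 gives 6000 nM, the lower of the two numbers, and the gap to compound 1 lies beyond the scatter of the method. Among the compounds with values here, no step between two measured compounds that differ in a single place is available, so the effect of any one group on the shared core is not known from these two values alone.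

Compound 3 `CC(C)(C)c1nc(-c2cnccn2)c2c(N)c(C#N)c(N)nc2n1` differs from compound 2 in one place: pyrazin-2-yl in place of butyl on an aromatic carbon. For this assay an upward step is expected from compound 2 to compound 3, of modest size, a 2.5-fold higher number from compound 2 to compound 3 (0.40 log units; beyond the scatter), because compound 2 starts from 6000 nM and the higher number of compound 1 shows that the core itself allows more. Compound 3 is therefore estimated at 15000 nM, with a range from 4000 nM to 60000 nM.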

Compound 3, solubility: 86000 nM
Estimate against measurement, compound 3: 5.7-fold (0.76 log units) below, and the stated range ends below it.
By their numbers in this assay, from the lowest: compound 2; then compounds 1 and 3 (each within the scatter of the next).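

In this assay, putting pyrazin-2-yl in place of butyl on this aromatic carbon, next to the ring nitrogen, gives a 14-fold higher number from compound 2 to compound 3 (1.16 log units; beyond the scatter), a large step. As the only single-place step shown, it establishes that this position on the shared core can, on its own, move the number well beyond the scatter, which the comparison of compound 1 and compound 2 could not show. No measurement at hand accounts for the size of this step.

From the compounds shown here alone, it remains open whether the step follows the aromatic ring as such or its two ring nitrogens, since a phenyl or a pyridin-2-yl group at this place would be needed to separate the two. Equally open, going by these compounds, is how a shorter chain such as methyl, or an amine, would read here.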